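The source may hold more compounds than are shown below. What is called first, only, known or untested is meant among the compounds shown, and "the series" means these compounds.

Measured compounds:
Compound 1, `O=C(O)c1cnc2cc(S(=O)(=O)O)ccc2c1O`, in an assay on isolated protein with malate dehydrogenase, cytoplasmic (Sus scrofa) as the target (a higher number here means a weaker inhibitor, a lower number a stronger inhibitor), gives 3090000 nM.
Compound 2, `O=C(O)c1ccc2c(O)c(C(=O)O)cnc2c1`, in this assay gives 1290000 nM.
Compound 3, `CN(C)c1ccc2c(O)c(C(=O)O)cnc2c1`, in this assay gives 372000 nM.

Compound 3 holds the lowest number of the three. Its nearest neighbour is compound 2, as the step of a 3.5-fold lower number from compound 2 to compound 3 (0.54 log units; beyond the scatter) shows, and compound 1 stands furthest away, as an 8.3-fold lower number from compound 1 to compound 3 (0.92 log units; beyond the scatter) shows. Compound 4, `O=C(O)c1cnc2cc(O)ccc2c1O`, has not yet been measured; it differs from compound 3 in one place: hydroxy in place of dimethylamino on an aromatic carbon. All three measured steps concern the group on this same aromatic carbon and bear on the change. They were a 2.4-fold lower number from compound 1 to compound 2 (0.38 log units; beyond the scatter), an 8.3-fold lower number from compound 1 to compound 3 (0.92 log units; beyond the scatter) and a 3.5-fold lower number from compound 2 to compound 3 (0.54 log units; beyond the scatter), all modest, and dimethylamino gave the lowest number among the groups tried. Hydroxy is a fourth group at this carbon that no measured step covers, so the direction is uncertain; a modest step is expected, most likely upward, back toward the numbers of compound 2 and compound 1. Compound 4 is therefore estimated to give 1000000 nM, with a range from 300000 nM to 3500000 nM, which means an expected step of a 2.7-fold higher number from compound 3 to compound 4 (0.43 log units; beyond the scatter).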

Compound 4, half-maximal inhibitory concentration: 955000 nM
For compound 4 the middle estimate is 1.0-fold (0.02 log units) above the measured one, within the range that was stated.
By their numbers in this assay, from the lowest: compound 3; then compounds 4 and 2 (each within the scatter of the next); then compound 1.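

In this assay, replacing dimethylamino with hydroxy on this aromatic carbon gives a 2.6-fold higher number from compound 3 to compound 4 (0.41 log units; beyond the scatter), so the lowest number at this carbon still belongs to the dimethylamino group of compound 3. Hydroxy and carboxy cannot be told apart here, as the step shows a 1.4-fold lower number from compound 2 to compound 4 (0.13 log units; within the scatter). Hydroxy does stand clear of sulfo, with a 3.2-fold lower number from compound 1 to compound 4 (0.51 log units; beyond the scatter), so the four groups now fall into three tiers: dimethylamino, then hydroxy and carboxy together, then sulfo.

Nothing measured here explains why the groups fall in this order. On these data alone, it also remains open whether the lower number of compound 3 depends on the nitrogen or on its two methyl groups, a question that a plain amine or a methoxy group at this carbon could help to answer.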